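The source may report more compounds than this note shows. Statements on the series, on what has been measured and on what is new or still open speak of the compounds shown alone.

In an in vitro ADME assay on microsomes from Gut (Homo sapiens) for metabolic stability, using NADPH (a lower number here means slower removal, a higher number faster removal of the compound), compound 2 `CC(C)(CO)CNC(=O)c1cc2cc(C#N)ccc2n1Cc1cc(Cl)cc(Cl)c1` reads < 6 mL.min-1.g-1 as a limit of the assay, not a number. Compound 1 `CCOc1ccc(OC(F)(F)F)cc1Cn1c(C(=O)NCC(C)(C)CO)cc2cc(C#N)ccc21` reads < 6 mL.min-1.g-1 as a limit too. Compound 3 `COc1ccc(Cl)cc1Cn1c(C(=O)NCC(C)(C)CO)cc2cc(C#N)ccc21` reads < 6 mL.min-1.g-1 as a limit as well.

Compound 4 `CCCOc1cccc(Cn2c(C(=O)NCC(C)(C)CO)cc3cc(C#N)ccc32)c1` has not yet been measured. It carries 3-propoxyphenyl in place of the 3,5-dichlorophenyl of compound 2, on a saturated chain carbon bound to an aromatic nitrogen, a change counted as 3-propoxyphenyl in place of 3,5-dichlorophenyl on a saturated chain carbon bound to an aromatic nitrogen in the two structures.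

Going by the values given here, the one measured step that bears on this change is a step that the two limits leave unreadable from compound 2 to compound 3 and it replaces the same 3,5-dichlorophenyl group. All the readings sit together, at the limit of < 6 mL.min-1.g-1 in this assay, at which 3 of the 3 values shown sit, so that step offers no size to carry over.

What is expected in this assay is therefore a step that the limit leaves unreadable from compound 2 to compound 4 with no step beyond the scatter foreseen and no firm direction. Compound 4 is estimated at 5 mL.min-1.g-1 with an expected range from 3 mL.min-1.g-1 to 10 mL.min-1.g-1 and it may well end at a limit of the assay again.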

Compound 4, intrinsic clearance in microsomes: 13 mL.min-1.g-1
Compound 4: middle estimate off by 2.6-fold (0.41 log units), on the low side; measured number outside the range, above it.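

In this assay, the group on the saturated chain carbon bound to an aromatic nitrogen can clearly move the read-out: the change to 3-propoxyphenyl gives an at least 2.1-fold higher number from compound 2 to compound 4 (0.33 log units; beyond the scatter), and it gives an at least 2.1-fold higher number from compound 3 to compound 4 (0.33 log units; beyond the scatter). Both steps are minimum sizes, and they lie beyond the scatter, so this position does not always leave compounds at the floor of the assay. The earlier compounds shown here could not show this, as the step between them cannot be read and their readings all stood at one limit: the limit of < 6 mL.min-1.g-1 in this assay, at which 3 of the 4 values shown sit.

As far as these compounds go, how large the two steps really are stays open, and so does which part of 3-propoxyphenyl matters, the oxygen or the length of the chain. A propyl chain without the oxygen, or a shorter ethoxy chain, on the phenyl ring would help separate the two.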